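Freeing one hydroxy group on compound 3

This account rests on a few compounds, and the source may have more. Where it says the series, first, only, none or still open, it means among the compounds named here.

In a functional assay on CNE2Z cells (Homo sapiens) for inhibition, read by MTT assay, with a stated time of 72 h (a higher number here means a weaker inhibitor, a lower number a stronger inhibitor), three compounds have been measured so far. Compound 1 (`C=CCc1ccc(OCc2c(Cl)cccc2Cl)c(-c2ccc(OCc3c(Cl)cccc3Cl)c(CC=C)c2)c1`) gives > 50000 nM, which is a limit and not a number. Compound 3 (`C=CCc1ccc(OCc2ccc(Cl)cc2Cl)c(-c2ccc(OCc3ccc(Cl)cc3Cl)c(CC=C)c2)c1`) gives > 50000 nM, which is likewise a limit. Compound 3 therefore has no exact position and stands at the limit of > 50000 nM in this assay, at which 2 of the 3 values shown sit. Among the measured compounds shown here, compound 2 (`C=CCc1ccc(O)c(-c2ccc(OCc3ccccc3)c(CC=C)c2)c1`), the only measured compound with a free hydroxy group, gives a numerical value of 30300 nM.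

Compound 4 (`C=CCc1ccc(OCc2ccc(Cl)cc2Cl)c(-c2ccc(O)c(CC=C)c2)c1`) differs from compound 3 by one change: hydrogen in place of 2,4-dichlorobenzyl on an oxygen on an aromatic ring. In words, hydrogen stands in place of 2,4-dichlorobenzyl on an oxygen on an aromatic ring, so that (2,4-dichlorobenzyl)oxy becomes hydroxy.

For the measured compounds named here, no measured step in this assay shows this change, and a limit gives no starting number for its size. A step towards stronger inhibition is still expected, with compound 4 landing near compound 2 at 30300 nM. Compound 4 may yet remain at the limit. The expected change is an at least 2.0-fold lower number from compound 3 to compound 4 (0.30 log units; that floor lies within the scatter). The estimated value for compound 4 is 25000 nM, with an expected range from 10000 nM to 50000 nM.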

Compound 4, half-maximal inhibitory concentration: 24200 nM
Estimate against measurement, compound 4: 1.0-fold (0.01 log units) above; low and high end bracket the measured number.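

In this assay, among the compounds shown here, replacing (2,4-dichlorobenzyl)oxy with hydroxy gives an at least 2.0-fold lower number from compound 3 to compound 4 (0.31 log units; beyond the scatter), the first readable step at this position; it is a floor only, as compound 3 stands at a limit and not at a number. The change brings the compound off that limit, which compound 3 and compound 1 share, and each of these two carries a substituted benzyl group on both oxygens: the limit of > 50000 nM in this assay, at which 2 of the 4 values shown sit. Freeing one oxygen is therefore enough to give a number even with a 2,4-dichlorobenzyl group still on the other oxygen, as compound 4 gives 24200 nM.

On these data alone, the true size of the step stays open, since the number for compound 3 lies beyond the limit of the assay. Also open, as far as these compounds go, is whether the hydroxy group itself matters on this oxygen, or whether a methoxy group, or an amine or a carboxylic acid on a short chain there, would also give a number in this assay.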